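The source may report more compounds than this note shows. Statements on the series, on what has been measured and on what is new or still open speak of the compounds shown alone.

The measured compounds:
compound 1, `Cc1ccc2c(c1)C1(C(=O)N2Cc2ccccc2)C(C#N)=C(N)Oc2cc3oc(-c4ccccc4)cc(=O)c3c(O)c21`, > 50000 nM
compound 2, `Cc1cccc2c1N(Cc1ccccc1)C(=O)C21C(C#N)=C(N)Oc2cc3oc(-c4ccccc4)cc(=O)c3c(O)c21`, > 50000 nM
compound 3, `COc1ccc2c(c1)C1(C(=O)N2Cc2ccccc2)C(C#N)=C(N)Oc2cc3oc(-c4ccccc4)cc(=O)c3c(O)c21`, > 50000 nM

In a functional assay on K562 cells (Homo sapiens) for antiproliferative activity, read by MTT assay, with a stated time of 48 h (a higher number here means a weaker inhibitor, a lower number a stronger inhibitor), compound 1 gives > 50000 nM, which is a limit of the assay and not a number. Compound 2 likewise gives > 50000 nM in this assay, again only a limit. Compound 3 stands at > 50000 nM in this assay, also a limit. All three measured values sit at the same point (the limit of > 50000 nM in this assay, at which 3 of the 3 values shown sit). Within the data shown here, the one step between measured compounds that differ in a single place, a step that the two limits leave unreadable from compound 1 to compound 3, cannot be read for that reason.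

Compound 4 is `N#CC1=C(N)Oc2cc3oc(-c4ccccc4)cc(=O)c3c(O)c2C12C(=O)N(Cc1ccccc1)c1ccc(F)cc12`; it differs from compound 3 by fluoro in place of methoxy on an aromatic carbon. Among the measured compounds shown here, no measured step bears on this change in a readable way: the only comparable change, methoxy in place of methyl, left both of its compounds at the limit. The step from compound 3 to compound 4 in this assay is therefore expected to be a step that the limit leaves unreadable from compound 3 to compound 4, with no movement beyond the limit foreseen. Compound 4 is estimated at 60000 nM in this assay, within 20000 nM to 200000 nM, and is most likely to be reported only as a limit.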

Compound 4, half-maximal inhibitory concentration: > 50000 nM
Compound 4: no number, only a limit; the forecaster's own chance of this, stated with the estimate: 85%; the middle value does not contradict the limit.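

Neither the step from compound 3 to compound 4 nor the step from compound 1 to compound 4 can be read, because all these values are limits and not numbers: the limit of > 50000 nM in this assay, at which 4 of the 4 values shown sit.

The compounds shown leave open which change to the shared core, if any, would give a readable value in this assay.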